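Saturating the Side Chain: From Compound 3 to Compound 4

The compounds below may be only part of what the source reports. "The series", "measured", "known", "first", "only" and "open" are said of these compounds alone.

Compound 1, `C/C=C\C=C\[C@](C)(O)C/C=C/[C@H]1[C@H](O)CC(=O)[C@@H]1CC/C=C\CCC(=O)OC`, in a functional assay on the whole organism with Rattus norvegicus as the target (on this read-out higher numbers stand for an effect only at larger amounts of compound and lower numbers for an effect already at smaller amounts), gives 0.306 mg/kg.
Compound 2, `C=C/C(C)=C/[C@](C)(O)C/C=C/[C@H]1[C@H](O)CC(=O)[C@@H]1CC/C=C\CCC(=O)OC`, in this assay gives 1.03 mg/kg.
Compound 3, `C/C=C(C)/C=C/[C@](C)(O)C/C=C/[C@H]1[C@H](O)CC(=O)[C@@H]1CC/C=C\CCC(=O)OC`, in this assay gives 0.185 mg/kg.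

Compound 3 has the lowest number of the three, but only its distance from compound 2 is beyond the scatter: a 5.6-fold lower number from compound 2 to compound 3 (0.75 log units; beyond the scatter). Against compound 1 the difference is within the scatter: a 1.7-fold lower number from compound 1 to compound 3 (0.22 log units; within the scatter). Compound 1 and compound 2 differ as a 3.4-fold higher number from compound 1 to compound 2 (0.53 log units; beyond the scatter).

Compound 4, `CCCCC(C)(O)C/C=C/[C@H]1[C@H](O)CC(=O)[C@@H]1CC/C=C\CCC(=O)OC`, is not yet measured. It differs from compound 3 in that (1-hydroxy-1-methylpentyl in place of 1-hydroxy-1,4-dimethylhexa-2,4-dien-1-yl on a saturated chain carbon bound to a double-bonded chain carbon). The three measured steps all alter substituents on the diene while keeping both double bonds, so none of them tests the loss of the double bonds that compound 4 brings. Among the measured compounds shown here, they show only that changes in this part of the molecule move this assay by modest amounts in either direction. For the measured compounds named here, with no direct precedent, compound 4 is expected to show a small to modest rise in number, a 3.2-fold higher number from compound 3 to compound 4 (0.51 log units; beyond the scatter), with wide uncertainty. The estimate for compound 4 is 0.6 mg/kg, within 0.15 mg/kg to 3 mg/kg.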

Compound 4, dose for half-maximal effect: 0.049 mg/kg
Compound 4: the middle estimate sits 12-fold (1.09 log units) above what was measured; measured number below the stated range.
By their numbers in this assay, from the lowest: compound 4; then compounds 3 and 1 (each within the scatter of the next); then compound 2.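

Exchanging 1-hydroxy-1,4-dimethylhexa-2,4-dien-1-yl for 1-hydroxy-1-methylpentyl gives a 3.8-fold lower number from compound 3 to compound 4 (0.58 log units; beyond the scatter) in this assay, so at this position the effect at small amounts of compound does not depend on keeping the two double bonds. The comparisons with the other two diene compounds point the same way, at a 6.2-fold lower number from compound 1 to compound 4 (0.80 log units; beyond the scatter) and at a 21-fold lower number from compound 2 to compound 4 (1.32 log units; beyond the scatter), the latter being the largest step in the set, and compound 4 now has the lowest number of the four, beyond the scatter of each. Nothing available explains why the saturated group gives the lower number.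

The compounds shown do not separate the loss of the double bonds from the change in chain length. They also leave open whether a longer saturated chain or a terminal phenyl ring in the same place would keep a number this low.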